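The compounds below may be only part of what the source reports. "The series", "measured", "known", "first", "only" and "open" are said of these compounds alone.

Compound 1, `CC(c1cc2cccnc2cc1F)n1cnc2ncc(-c3cnn(C)c3)nc21`: in an ADME assay on microsomes from liver (Rattus norvegicus) for metabolic stability, read by LC-MS, using NADPH, with stated times of 5 min and 30 min, tested at 1 uM (a lower number here means slower removal, a higher number faster removal of the compound), compound 1 gives 18 uL/min.
Compound 2, `CC(c1c(F)cc2ncccc2c1F)n1cnc2ncc(-c3cnn(CCO)c3)nc21`: in this assay compound 2 gives 10 uL/min.

Compound 2 has the lower of the two numbers, yet its gap to compound 1 lies within the scatter, so the two cannot be told apart. Compound 3, `COC(=O)c1ccc(-c2cnc3ncn(C(C)c4c(F)cc5ncccc5c4F)c3n2)cc1F`, is not yet measured. It differs from compound 2 in one place: 3-fluoro-4-(methoxycarbonyl)phenyl in place of 1-(2-hydroxyethyl)-1H-pyrazol-4-yl on an aromatic carbon. Among the compounds with values here, no measured pair shows this change, so nothing fixes the size of the step. A rise beyond the scatter is expected in this assay, with the step estimated at a 3.0-fold higher number from compound 2 to compound 3 (0.48 log units; beyond the scatter). Compound 3 is expected to give about 30 uL/min, between 12 uL/min and 75 uL/min.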

Compound 3, intrinsic clearance in a liver preparation (reported as CLH), per the amount of preparation that the assay uses: 179 uL/min
Compound 3: the middle estimate sits 6.0-fold (0.78 log units) below what was measured, and the stated range ends below it.
By their numbers in this assay, from the lowest: compounds 2 and 1 (each within the scatter of the next); then compound 3.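

Replacing 1-(2-hydroxyethyl)-1H-pyrazol-4-yl with 3-fluoro-4-(methoxycarbonyl)phenyl gives an 18-fold higher number from compound 2 to compound 3 (1.25 log units; beyond the scatter) in this assay and shows that this position on the shared core can move the number far beyond the scatter. The earlier compounds shown here, which could not be told apart, gave no sign of a range this wide. Nothing available explains the rise. On these data alone, the ring, the fluorine and the methoxycarbonyl group all enter together, so which of them carries the step stays open. A carboxylic acid or an amide in place of the methoxycarbonyl group on the same ring would begin to separate them.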